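A few compounds are considered here, and "the series" means these few. Any claim that something is new, unique, unknown or untested is made for them only; others in the source may bear on it.

Measured compounds:
- compound 1, `O=C(Nc1cccc(-n2cc(-c3ccncc3)c(-c3cc(O)cc(Cl)c3)n2)c1)Nc1ccc(Cl)c(C(F)(F)F)c1`, in a functional assay on KM12 cells (Homo sapiens) for inhibition, read by sulforhodamine B assay, with a stated time of 48 h, tested at 1 uM (a higher number here means a weaker effect of the compound at the concentration tested, a lower number a stronger effect), gives 56%
- compound 2, `O=C(Nc1cccc(-n2cc(-c3ccncc3)c(-c3cc(O)cc(Cl)c3)n2)c1)Nc1ccc(Cl)c(Cl)c1`, in this assay gives 72%
- compound 3, `COc1cc(Cl)cc(-c2nn(-c3cccc(NC(=O)Nc4cc(C(F)(F)F)cc(C(F)(F)F)c4)c3)cc2-c2ccncc2)c1`, in this assay gives 31%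

Compound 2 stands highest of the three numbers in this assay; its nearest neighbour is compound 1, and the step of a number 16 percentage points higher from compound 1 to compound 2 (beyond the scatter) lies beyond the scatter. Among the measured compounds shown here, compound 3, which carries a methoxy but also a different aryl urea, gives the lowest number, and no single-point step connects it to compound 2.

Compound 4, `COc1cc(Cl)cc(-c2nn(-c3cccc(NC(=O)Nc4ccc(Cl)c(Cl)c4)c3)cc2-c2ccncc2)c1`, differs from compound 2 by methyl in place of hydrogen on an oxygen on an aromatic ring. For the measured compounds named here, no measured step covers this change; the two compounds that carry hydroxy differ from the one carrying methoxy in a second place as well. The expected step is therefore small, a number 7 percentage points lower from compound 2 to compound 4 (within the scatter), well within the scatter. Compound 4 is estimated to give 65% in this assay, between 40% and 85%.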

Compound 4, a percentage reported as activity, at one concentration (the size of the read-out at that concentration, not a potency): 72%
The estimate for compound 4 lay 7 percentage points below the measured number; the range from low to high includes it.
By their numbers in this assay, from the lowest: compound 3; then compound 1; then compounds 2 and 4 (each within the scatter of the next).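

Methyl in place of hydrogen on an oxygen on an aromatic ring leaves the read-out in this assay flat, the step showing no change at the digits printed from compound 2 to compound 4 (within the scatter). Among the compounds shown here, this is the first pair that isolates hydroxy against methoxy, since compound 3 also differs from compound 1 and compound 2 in its aryl urea. Nothing available here explains why the two numbers match.

On these data alone, whether an ethoxy, a longer chain on this oxygen or an amine in its place would keep the number remains open. So does whether the same change behaves alike with the aryl ureas of compound 1 and compound 3.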